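Swapping furan for methoxybenzyl on a weakly cytotoxic amide

A few compounds are considered here, and "the series" means these few. Any claim that something is new, unique, unknown or untested is made for them only; others in the source may bear on it.

Measured in a functional assay on HCT-116 cells (Homo sapiens) for cytotoxicity, read by MTT assay, with a stated time of 72 h; on this read-out higher numbers stand for weaker inhibition and lower numbers for stronger inhibition:
Compound 1 `N[C@H]1CC[C@H](Nc2c(C(=O)NCc3ccco3)nc(Br)c3cccnc23)CC1`: > 10000 nM
Compound 2 `O=C(NCc1ccc(F)cc1)c1nc(Br)c2cccnc2c1NCCCNc1c(C(=O)NCc2ccc(F)cc2)nc(Br)c2cccnc12`: > 20000 nM
Compound 3 `Nc1ccc(Nc2c(C(=O)NCc3ccc(F)cc3)nc(Br)c3cccnc23)cc1`: 10000 nM

In this assay compound 1 gives > 10000 nM, which is a limit of the assay and not a number. Compound 2 also gives only a limit, > 20000 nM. Compound 3 alone gives an actual number, 10000 nM.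

Compound 4 `COc1cccc(CNC(=O)c2nc(Br)c3cccnc3c2N[C@H]2CC[C@H](N)CC2)c1` departs from compound 1 in one place: 3-methoxyphenyl in place of furan-2-yl on a saturated chain carbon bound to an amide-type nitrogen. Here 3-methoxyphenyl stands in place of furan-2-yl on a saturated chain carbon bound to an amide-type nitrogen.

Among the compounds with values here, no two measured compounds differ in one place, so the data offer no direct measure of such a change. The expectation therefore leans on compound 3, with its value of 10000 nM, and predicts little movement, perhaps slightly stronger inhibition. The expected change is an at least 1.1-fold lower number from compound 1 to compound 4 (0.04 log units; that floor lies within the scatter). For compound 4 the estimated value is 9000 nM, with an expected range from 3000 nM to 25000 nM.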

Compound 4, half-maximal inhibitory concentration: 6000 nM
For compound 4 the middle estimate is 1.5-fold (0.18 log units) above the measured one, and the stated range covers the measured number.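

In this assay, 3-methoxyphenyl in place of furan-2-yl gives an at least 1.6-fold lower number from compound 1 to compound 4 (0.22 log units; that floor lies within the scatter). Compound 4 gives 6000 nM, an actual number, so a readable value is reached with the larger aromatic ring on this saturated chain carbon bound to an amide-type nitrogen. The true size of the step stays unknown because compound 1 carries a limit of the assay and not a number: the limit of > 10000 nM in this assay, at which 1 of the 4 values shown sits.

The compounds shown leave open whether the ring itself or its methoxy group accounts for the value of compound 4, a question that a plain benzyl group on the amide nitrogen would address. They also leave open how a longer chain carrying the same 3-methoxyphenyl ring would read in this assay.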